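A few compounds are considered here, and "the series" means these few. Any claim that something is new, unique, unknown or untested is made for them only; others in the source may bear on it.

Measured compounds in a functional assay for antagonist activity at Alpha-1A adrenergic receptor (Oryctolagus cuniculus); on this read-out lower numbers stand for tighter binding and higher numbers for weaker binding:
Compound 1, `CN(C)C(=O)c1cccnc1NCCCN1CCN(c2ccccc2O)CC1`: 5.01 nM
Compound 2, `CCOc1ccccc1N1CCN(CCCNc2ncccc2C(=O)N(C)C)CC1`: 0.501 nM
Compound 3, `CCCc1ccccc1N1CCN(CCCNc2ncccc2C(=O)N(C)C)CC1`: 0.2 nM

Compound 3 gives the lowest number of the three. Compound 2 stands nearest to it, as shown by a 2.5-fold lower number from compound 2 to compound 3 (0.40 log units; beyond the scatter), and compound 1 stands furthest, as shown by a 25-fold lower number from compound 1 to compound 3 (1.40 log units; beyond the scatter).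

Compound 4, `COc1ccc(N2CCN(CCCNc3ncccc3C(=O)N(C)C)CC2)c(OC)c1`, is not yet measured. Its change from compound 3 is 2,4-dimethoxyphenyl in place of 2-propylphenyl on an amine nitrogen in a ring.

Two of the measured steps bear on this change, since both alter the same aromatic ring attached to the ring nitrogen. The step of a 10-fold lower number from compound 1 to compound 2 (1.00 log units; beyond the scatter) shows that capping the oxygen with ethyl lowers the number. The step of a 2.5-fold lower number from compound 2 to compound 3 (0.40 log units; beyond the scatter) shows that propyl in place of ethoxy lowers it further. A 2-methoxy group is close to the ethoxy of compound 2, so compound 4 is expected to land nearer compound 2 than compound 3. Among the measured compounds shown here, no measured compound carries a second substituent on this ring, so the effect of the added 4-methoxy is unknown from these data.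

Compound 4 is therefore estimated at 0.6 nM, with a range from 0.15 nM to 2.5 nM. This expected step is a 3.0-fold higher number from compound 3 to compound 4 (0.48 log units; beyond the scatter).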

Compound 4, dissociation constant: 31.6 nM
For compound 4 the middle estimate is 53-fold (1.72 log units) below the measured one, outside the stated range (above it).
By their numbers in this assay, from the lowest: compound 3; then compound 2; then compound 1; then compound 4.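

In this assay, the 2,4-dimethoxyphenyl group on the amine nitrogen in a ring gives the highest number of the four compounds, with a 160-fold higher number from compound 3 to compound 4 (2.20 log units; beyond the scatter) and a 63-fold higher number from compound 2 to compound 4 (1.80 log units; beyond the scatter). Among the compounds shown here, it also goes past the 2-hydroxyphenyl group, the highest of the earlier three, with a 6.3-fold higher number from compound 1 to compound 4 (0.80 log units; beyond the scatter), so the earlier compounds' span at this position does not mark its upper end. Each earlier step in the listed order lowered the number, whereas this change shows that an aryl group with two methoxy groups can raise it sharply, and no measured evidence here accounts for that rise.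

Two things change together in compound 4, a methoxy in place of the ethoxy or propyl and a second methoxy on the ring, and the compounds shown leave open how much of the rise belongs to each. A 2-methoxyphenyl group alone would separate the two, and whether a chlorine or a methyl in place of the 4-methoxy would also raise the number remains an open question.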